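The source may hold more compounds than are shown below. What is called first, only, known or untested is meant among the compounds shown, and "the series" means these compounds.

Compounds measured so far:
compound 1 `CCN(CC)c1ccc(NC(=O)c2c(-c3c(Cl)cccc3Cl)noc2C)cc1Cl`, > 10000 nM
compound 2 `CCC(CC)c1ccc(NC(=O)c2c(-c3c(Cl)cccc3Cl)noc2C)cc1`, > 10000 nM
compound 3 `CCN(CC)c1ccc(NC(=O)c2c(-c3c(Cl)cccc3Cl)noc2C)c(C)c1`, 37 nM

In an assay on isolated protein for binding affinity to growth hormone secretagogue receptor type 1 (Homo sapiens) (on this read-out higher numbers stand for weaker inhibition and lower numbers for stronger inhibition), compound 2 gives > 10000 nM, which is a limit of the assay and not a number. Compound 1 likewise reaches only a limit, > 10000 nM in this assay. Within the data shown here, these two values make up (the limit of > 10000 nM in this assay, at which 2 of the 3 values shown sit), so compound 2 sits with compound 1 at the weak end of what has been seen, while compound 3, with 37 nM in this assay, is the one compound for which a number is known.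

Compound 4 `CCN(CC)Cc1ccc(NC(=O)c2c(-c3c(Cl)cccc3Cl)noc2C)cc1` has not yet been measured in this assay. It differs from compound 2 by (diethylamino)methyl in place of pentan-3-yl on an aromatic carbon, para to a large group. Among the measured compounds shown here, no step between measured compounds describes this change directly. Compound 3, which also carries a diethylamino group, shows a numbered value, whereas compound 2 only a limit, so a move in the direction of stronger binding beyond the scatter is expected for compound 4, though with wide uncertainty. Compound 4 is therefore estimated at 800 nM in this assay, in a range of 60 nM to 10000 nM, an expected step of an at least 12-fold lower number from compound 2 to compound 4 (1.09 log units; beyond the scatter).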

Compound 4, half-maximal inhibitory concentration: > 10000 nM
Compound 4: no number, only a limit; the forecaster's own chance of this, stated with the estimate: 30%; at least 12-fold (1.09 log units) between middle value and limit.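

Among these compounds, compound 2 and compound 4 each give only a limit of the assay and not a number, so no step between them can be read: the limit of > 10000 nM in this assay, at which 3 of the 4 values shown sit.

The compounds shown leave open how (diethylamino)methyl and pentan-3-yl truly compare, and which structural feature sets compound 3, the only compound with a number, apart.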